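Removing the benzylamino group: what solubility to expect

A few compounds are considered here, and "the series" means these few. Any claim that something is new, unique, unknown or untested is made for them only; others in the source may bear on it.

Measured compounds and their solubility values:
- compound 1 `Nc1nccc(-c2ccc3c(Nc4ccccc4)n[nH]c3c2)n1`: 3000 nM
- compound 2 `COc1cc(-c2ccnc(N)n2)cc2[nH]nc(N)c12`: > 100000 nM, which is a limit of the assay, not a number
- compound 3 `Nc1nccc(-c2ccc3c(NCc4ccccc4)n[nH]c3c2)n1`: 17000 nM

In a physicochemical assay for solubility, read by LC-MS, in phosphate buffer, measured as kinetic solubility, with a stated time of 24 h, at 25 degrees C, at pH 7.4 (a higher number here means a more soluble compound, a lower number a less soluble compound), compound 3 gives 17000 nM, the higher of the two plain numbers. Its nearest neighbour is compound 1, and the step of a 5.7-fold higher number from compound 1 to compound 3 (0.75 log units; beyond the scatter). For compound 2 the assay reports only (the limit of > 100000 nM in this assay, at which 1 of the 3 values shown sits).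

Compound 4 `Nc1nccc(-c2ccc3cn[nH]c3c2)n1` keeps the shared core of compound 3 but drops the side group entirely: hydrogen in place of benzylamino on an aromatic carbon. Going by the values given here, only one measured step touches this part of the molecule, the swap of phenyl for benzyl from compound 1 to compound 3, and it was modest. Cutting the whole benzylamino group away is a larger change than that swap, so the measured step gives a direction more than a size. Compound 4 is expected to land higher in this assay, with the step of a 3.5-fold higher number from compound 3 to compound 4 (0.55 log units; beyond the scatter), and its estimated value is 60000 nM, within a range of 15000 nM to 200000 nM.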

Compound 4, solubility: 215000 nM
Beside the measured number, compound 4's estimate is 3.6-fold (0.55 log units) below it; measured number above the stated range.
By their numbers in this assay, from the lowest: compound 1; then compound 3; then compound 4.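

In this assay, going by these compounds alone, the earlier compounds showed only one side group swapped for another on this aromatic carbon, a 5.7-fold higher number from compound 1 to compound 3 (0.75 log units; beyond the scatter). Removing the side group altogether moves the number much further, with a 13-fold higher number from compound 3 to compound 4 (1.10 log units; beyond the scatter) and a 72-fold higher number from compound 1 to compound 4 (1.86 log units; beyond the scatter). Among these three compounds, then, the choice between hydrogen and either side group at this position matters more than the choice between the benzyl and phenyl forms of that group. What the compounds shown leave open is where a small group on this carbon, such as methyl, or a short chain ending in a carboxylic acid, would fall between hydrogen and the larger side groups. Nothing shown here gives a reason for the size of these steps.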